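Quinone pyrazoles: chloro replaces methyl on the aryl ring

This account rests on a few compounds, and the source may have more. Where it says the series, first, only, none or still open, it means among the compounds named here.

Two quinone-bearing pyrazoles have been tested. Compound 1 `O=C1C=CC(=O)C(c2cc(-c3ccc(Cl)cc3)nn2-c2ccccc2)=C1` gives 42400 nM in a functional assay on cells (Cancer cell lines, Homo sapiens) for cytotoxicity, read by sulforhodamine B assay, with a stated time of 48 h; a lower number here means a stronger inhibitor of growth, a higher number a weaker inhibitor of growth. Compound 2 `Cc1ccc(-c2cc(C3=CC(=O)C=CC3=O)n(-c3ccc(S(N)(=O)=O)cc3)n2)cc1` gives 42400 nM in this assay, level with compound 1 at the digits shown, within the scatter. Compound 3 `NS(=O)(=O)c1ccc(-n2nc(-c3ccc(Cl)cc3)cc2C2=CC(=O)C=CC2=O)cc1` is the untested partner of compound 2; the change is chloro in place of methyl on an aromatic carbon, the same difference read one bond further out being 4-methylphenyl to 4-chlorophenyl. Among the measured compounds shown here, no step between measured pairs exists to guide the size. Since compound 1 carries chloro at 42400 nM and compound 2 methyl at 42400 nM, no step beyond the scatter is expected, a 1.0-fold lower number from compound 2 to compound 3 (0.00 log units; within the scatter). Compound 3 is estimated at 42000 nM, range 18000 nM to 95000 nM.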

Compound 3, concentration for 50% growth inhibition: 17600 nM
Estimate against measurement, compound 3: 2.4-fold (0.38 log units) above; the whole stated range lies above it.
By their numbers in this assay, from the lowest: compound 3; then compounds 1 and 2 (each within the scatter of the next).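

In this assay, chloro in place of methyl on the aromatic carbon para to a large group gives a 2.4-fold lower number from compound 2 to compound 3 (0.38 log units; beyond the scatter), so this position responds to the change when sulfamoyl is present in both partners. With chloro held, sulfamoyl in place of hydrogen on an aromatic carbon gives a 2.4-fold lower number from compound 1 to compound 3 (0.38 log units; beyond the scatter), the first step read for that group. No measurement on hand bears on the origin of either step.

On these data alone, whether an amine or a carboxylic acid at the chloro position would lower the number further remains open. So does the size of the chloro-for-methyl step without sulfamoyl.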